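The source may report more compounds than this note shows. Statements on the series, on what has been measured and on what is new or still open speak of the compounds shown alone.

In an ADME assay on Vero cells (Chlorocebus sabaeus) for cytotoxicity, read by reporter gene assay, with a stated time of 4 days (on this read-out lower numbers stand for stronger inhibition and higher numbers for weaker inhibition), three compounds have been measured:

Compound 1 (`CCCCCC(=O)NCC(C)(C)CC1=C(O)C(=O)c2ccccc2C1=O`): 46600 nM
Compound 2 (`CCCCCCC(=O)NCC(C)(C)CC1=C(O)C(=O)c2ccccc2C1=O`): 24800 nM
Compound 3 (`CCCCCCCCCCCC(=O)NCC(C)(C)CC1=C(O)C(=O)c2ccccc2C1=O`): 13900 nM

Compound 3 stands at the low end of this short series, but it shares that end with compound 2. The data show a 1.8-fold lower number from compound 2 to compound 3 (0.25 log units; within the scatter). Only the comparison with compound 1 separates it clearly, with a 3.4-fold lower number from compound 1 to compound 3 (0.53 log units; beyond the scatter).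

Compound 4 (`CCCCCCCCCCCCCCCCCC(=O)NCC(C)(C)CC1=C(O)C(=O)c2ccccc2C1=O`) differs from compound 3 by hexyl in place of hydrogen on a saturated chain carbon, ten or more bonds along the chain from a carbonyl carbon.

Among the measured compounds shown here, the nearest precedent is the same hexyl change made five bonds along the chain from a carbonyl carbon, which gave a 3.4-fold lower number from compound 1 to compound 3 (0.53 log units; beyond the scatter), a modest step. The shorter extensions gave a 1.9-fold lower number from compound 1 to compound 2 (0.27 log units; within the scatter) and a 1.8-fold lower number from compound 2 to compound 3 (0.25 log units; within the scatter). All three steps point downward, and none of the three compounds goes against this, but no measured chain is longer than that of compound 3. In this assay, a further small fall is therefore expected, probably not beyond the scatter. The expected change is a 1.5-fold lower number from compound 3 to compound 4 (0.17 log units; within the scatter). The estimate for compound 4 is 9500 nM, with an expected range of 4000 nM to 24000 nM.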

Compound 4, half-maximal inhibitory concentration: 5760 nM
Estimate against measurement, compound 4: 1.6-fold (0.22 log units) above; low and high end bracket the measured number.
By their numbers in this assay, from the lowest: compound 4; then compounds 3, 2 and 1 (each within the scatter of the next, the first and the last beyond it).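

In this assay, the hexyl change still lowers the number when made on the longer chain, with a 2.4-fold lower number from compound 3 to compound 4 (0.38 log units; beyond the scatter), so the direction seen among the shorter chains holds at a chain longer than any measured before. Unlike the two shorter extensions, whose steps stayed within the scatter, this single step lies beyond it, and no levelling off appears up to the chain of compound 4. Taken over longer spans, the same downward direction gives a 4.3-fold lower number from compound 2 to compound 4 (0.63 log units; beyond the scatter) and an 8.1-fold lower number from compound 1 to compound 4 (0.91 log units; beyond the scatter), so all four compounds fall in order of chain length and none goes against the pattern, although the neighbouring pairs among compounds 1, 2 and 3 lie within the scatter of each other.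

As far as these compounds go, whether a longer chain than that of compound 4 would carry the fall further, and what an amine or a carboxylic acid in place of the hexyl would do to the number, stays open. No evidence at hand accounts for the fall along this series.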